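The source may hold more compounds than are shown below. What is called first, only, known or untested is meant among the compounds shown, and "the series" means these compounds.

Among the compounds with values here, compound 2 `Cc1cc(C)cc(COc2ccc(-c3cc(CN4CCN(Cc5ccc(C(F)(F)F)cc5)CC4)no3)cc2)c1` stands lowest of the two numbers so far. In a functional assay on Huh-7 cells (Homo sapiens) for antiproliferative activity, read by sulforhodamine B assay, with a stated time of 72 h (a lower number here means a stronger inhibitor, a higher number a weaker inhibitor), compound 2 gives 600 nM, and its nearest neighbour, compound 1 `Cc1ccc(COc2ccc(-c3cc(CN4CCN(Cc5ccc(C(F)(F)F)cc5)CC4)no3)cc2)cc1`, gives 1500 nM. Within the data shown here, the one step between measured compounds, a 2.5-fold lower number from compound 1 to compound 2 (0.40 log units; beyond the scatter), came from swapping 4-methylphenyl for 3,5-dimethylphenyl on the saturated chain carbon bound to an oxygen on an aromatic ring.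

Compound 3 `N#Cc1ccccc1COc1ccc(-c2cc(CN3CCN(Cc4ccc(C(F)(F)F)cc4)CC3)no2)cc1` changes that same position again: 2-cyanophenyl in place of 3,5-dimethylphenyl on a saturated chain carbon bound to an oxygen on an aromatic ring. Among the measured compounds shown here, the methyl groups that went with the lower number of compound 2 are gone, and a nitrile appears instead; no measured step covers a nitrile at this place. For the measured compounds named here, the only step that bears on it, a 2.5-fold lower number from compound 1 to compound 2 (0.40 log units; beyond the scatter), is modest, so its reversal would be expected to raise the number back toward that of compound 1, with the nitrile an open question. An increase in this assay is therefore expected for compound 3, of about a 2.5-fold higher number from compound 2 to compound 3 (0.40 log units; beyond the scatter). Compound 3 is estimated at 1500 nM, within a range from 500 nM to 5000 nM.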

Compound 3, half-maximal inhibitory concentration: 5000 nM
Beside the measured number, compound 3's estimate is 3.3-fold (0.52 log units) below it, within the range that was stated.
By their numbers in this assay, from the lowest: compound 2; then compound 1; then compound 3.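

In this assay, the change to 2-cyanophenyl gives an 8.3-fold higher number from compound 2 to compound 3 (0.92 log units; beyond the scatter) and so runs against the earlier step, showing that this position can move the number in either direction and by more than the methyl groups alone had suggested. The nitrile does more than cancel the second methyl group, as the comparison with the single-methyl compound gives a 3.3-fold higher number from compound 1 to compound 3 (0.52 log units; beyond the scatter) and leaves 2-cyanophenyl with the highest number of the three groups at this place. No measurement bears on why the number rises with this change.

Compound 3 loses the methyl groups and gains the nitrile in a single change, so the compounds shown do not separate the effect of the one from that of the other. Also open, from the compounds shown here alone, is where a plain unsubstituted phenyl, a methoxyphenyl or an aminophenyl at this place would fall relative to compound 2 and compound 3, and whether the order of these groups would hold with the rest of the molecule changed.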